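A few compounds are considered here, and "the series" means these few. Any claim that something is new, unique, unknown or untested is made for them only; others in the source may bear on it.

Measured in an assay on cells for inhibition of MAP kinase-interacting serine/threonine-protein kinase 1 (Homo sapiens), read by mobility shift assay, with stated times of 10 min and 60 min, in the presence of a further agent that is not named here; a higher number here means a weaker inhibitor, a lower number a stronger inhibitor:

compound 1 `CC(C)Oc1cc(-c2cncc(-c3cnn(C4COC4)c3)c2)ccc1C(N)=O`: 200 nM
compound 2 `CC(C)Oc1cc(-c2cncc(-c3cnn(C(C)C)c3)c2)ccc1C(N)=O`: 85 nM
compound 3 `COc1cc(-c2cccnc2)ccc1C(N)=O`: 2800 nM

Compound 3 carries the highest number of the three; its nearest neighbour is compound 1 and the furthest compound 2, both well beyond the scatter. Compound 4 `CC(C)Oc1cc(-c2cccnc2)ccc1C(N)=O` is the next point, differing from compound 3 by isopropyl in place of methyl on an oxygen on an aromatic ring. Among the measured compounds shown here, no measured step covers this change directly: the only step in hand, a 2.4-fold lower number from compound 1 to compound 2 (0.37 log units; beyond the scatter), concerns a different group on a different atom and is modest in size. Compounds 1 and 2 both carry the isopropoxy group and give much lower numbers than compound 3, but they also differ from compound 3 in the second ring system, so their values cannot be assigned to the alkoxy change alone. For the measured compounds named here, with no direct precedent, a small to moderate move toward a lower number is the expectation for compound 4, a 1.9-fold lower number from compound 3 to compound 4 (0.27 log units; within the scatter), with wide uncertainty. The estimate for compound 4 in this assay is 1500 nM, expected between 600 nM and 4000 nM.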

Compound 4, half-maximal inhibitory concentration: 880 nM
Compound 4: the middle estimate sits 1.7-fold (0.23 log units) above what was measured; low and high end bracket the measured number.
By their numbers in this assay, from the lowest: compound 2; then compound 1; then compound 4; then compound 3.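

In this assay, methoxy to isopropoxy can now be read on its own, and it gives a 3.2-fold lower number from compound 3 to compound 4 (0.50 log units; beyond the scatter) with the rest of the structure unchanged. With the isopropoxy group held constant, hydrogen in place of either substituent on the aromatic carbon also raises the number, giving a 10-fold higher number from compound 2 to compound 4 (1.02 log units; beyond the scatter) for the 1-isopropyl-1H-pyrazol-4-yl group and a 4.4-fold higher number from compound 1 to compound 4 (0.64 log units; beyond the scatter) for the 1-(oxetan-3-yl)-1H-pyrazol-4-yl group. No evidence at hand accounts for any of these steps.

The compounds shown leave open whether the methoxy to isopropoxy step keeps its size on the core of compound 2. They also leave open how ethoxy or a longer alkoxy chain compares with isopropoxy on that oxygen, and how an amine reads in place of isopropyl on the aromatic nitrogen.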